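Fluoro to methylsulfanyl in an antiproliferative series

A few compounds are considered here, and "the series" means these few. Any claim that something is new, unique, unknown or untested is made for them only; others in the source may bear on it.

Compound 1 `O=C(CCc1cccc2c1B(O)OC2)Nc1ccc([N+](=O)[O-])cc1` gives 83000 nM
Compound 2 `O=C(CCc1cccc2c1B(O)OC2)Nc1cccc(-c2ccc(F)cc2)c1` gives 93 nM

In a functional assay on SK-OV-3 cells (Homo sapiens) for antiproliferative activity, read by MTT assay, with a stated time of 72 h (on this read-out higher numbers stand for weaker inhibition and lower numbers for stronger inhibition), compound 2 stands lowest of the two, and it gives 93 nM, while compound 1 gives 83000 nM on the same measure. The gap between these two compounds lies far beyond the scatter. Compound 3 `CSc1ccc(-c2cccc(NC(=O)CCc3cccc4c3B(O)OC4)c2)cc1` has not yet been measured. It differs from compound 2 by methylsulfanyl in place of fluoro on an aromatic carbon with methylsulfanyl in place of fluoro on an aromatic carbon. Among the measured compounds shown here, no measured pair shows this change on its own. The expected step of a 1.6-fold higher number from compound 2 to compound 3 (0.21 log units; within the scatter) stays within the scatter in this assay and leans slightly towards a higher number. For compound 3 the estimate is 150 nM with an expected range from 40 nM to 600 nM on this measure.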

Compound 3, half-maximal inhibitory concentration: 140 nM
Estimate against measurement, compound 3: 1.1-fold (0.03 log units) above; low and high end bracket the measured number.
By their numbers in this assay, from the lowest: compounds 2 and 3 (each within the scatter of the next); then compound 1.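

In this assay, among the compounds shown here, the change from 4-fluorophenyl to 4-(methylsulfanyl)phenyl gives a 1.5-fold higher number from compound 2 to compound 3 (0.18 log units; within the scatter), the first reading of a single change at this position. At this place on the aromatic ring, para to a large group, 2 heavy atoms including a sulfur stand in for one fluorine, and the two compounds cannot be told apart on this measure. Nothing available explains this result.

The compounds shown leave open how an amine, a carboxylic acid or a longer chain would read at this same position. They also leave open whether the ring would read the same with hydrogen there and neither group present.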